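Amide nitrogen substituent swap in a chlorophenyl butanamide series

A few compounds are considered here, and "the series" means these few. Any claim that something is new, unique, unknown or untested is made for them only; others in the source may bear on it.

Three measured compounds share the same chlorophenyl and isopropyl arrangement: compound 1 `CC(C)C(c1ccc(Cl)cc1)S(=O)(=O)Nc1nccs1`, compound 2 `CC(C)C(C(N)=O)c1ccc(Cl)cc1` and compound 3 `CC(C)[C@H](C(=O)NC(C)(C)C)c1ccc(Cl)cc1`. In a functional assay on CHO cells for agonist activity at Free fatty acid receptor 2 (Homo sapiens), read by cAMP accumulation (a lower number here means a stronger inhibitor, a higher number a weaker inhibitor), compound 1 returns only the limit > 100000 nM. Compound 2 likewise gives only the limit > 100000 nM in this assay. Compound 3 also sits at the limit > 100000 nM in this assay; since every value rests at the limit of > 100000 nM in this assay, at which 3 of the 3 values shown sit, compound 3 cannot be separated from the others on the numbers shown. Compound 4 `CC(C)[C@H](C(=O)Nc1ccccn1)c1ccc(Cl)cc1` differs from compound 3 by pyridin-2-yl in place of tert-butyl on an amide-type nitrogen. Among the measured compounds shown here, no measured step exists to size this change. For compound 4 a shift beyond the scatter towards stronger activity is nevertheless expected, an at least 10-fold lower number from compound 3 to compound 4 (1.00 log units; beyond the scatter). Compound 4 is estimated at 10000 nM, within 1000 nM to 100000 nM, with a real chance that only a limit is reported again.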

Compound 4, half-maximal inhibitory concentration: 1400 nM
For compound 4 the middle estimate is 7.1-fold (0.85 log units) above the measured one; measured number inside the range.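

Pyridin-2-yl in place of tert-butyl on the amide-type nitrogen gives an at least 71-fold lower number from compound 3 to compound 4 (1.85 log units; beyond the scatter) in this assay, the only step here that reaches a measurable number. As far as these compounds go, for compound 3 the value > 100000 nM is a limit, so the true size of the step stays unknown. The substituent on this nitrogen therefore separates a readable value from the limit, at least between these two compounds.

Open, from the compounds shown here alone, is whether phenyl or pyridin-3-yl on the same nitrogen would keep this value, which would separate the ring itself from the placing of its nitrogen. Also open, going by these compounds, is how a longer chain in place of the isopropyl would read with pyridin-2-yl retained.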